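The source may hold more compounds than are shown below. What is called first, only, known or untested is meant among the compounds shown, and "the series" means these compounds.

Working notes on the series. The shared core carries a 1H-indol-3-yl group and an amino group, and the members differ only in the group on a saturated ring carbon. Compound 1 `N#CC1=C(N)OC(c2c[nH]c3ccccc23)=C(C#N)C1c1cccc2ccccc12` bears naphthalen-1-yl there; in a functional assay, tested at 100 ug/mL (on this read-out lower numbers stand for a weaker effect and higher numbers for a stronger effect at the one concentration tested), compound 1 gives 6.8%, the lowest of the three numbers measured. Compound 2 `N#CC1=C(N)OC(c2c[nH]c3ccccc23)=C(C#N)C1c1ccccc1` carries phenyl at that carbon, and in this assay compound 2 gives 19.3%. Compound 3 `N#CC1=C(N)OC(c2c[nH]c3ccccc23)=C(C#N)C1c1ccc(F)cc1` carries 4-fluorophenyl; in this assay compound 3 gives 16.2%. Between the two monocyclic analogues the step of a number 3.1 percentage points lower from compound 2 to compound 3 (within the scatter) stays within the scatter.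

Compound 4 `N#CC1=C(N)OC(c2c[nH]c3ccccc23)=C(C#N)C1c1ccccc1Cl` is not yet measured. Relative to compound 1 the change is 2-chlorophenyl in place of naphthalen-1-yl on a saturated ring carbon. Among the compounds with values here, two measured steps bear on it: from compound 1 the exchange of naphthalen-1-yl for one six-membered aromatic ring of carbon only gave a number 12.5 percentage points higher from compound 1 to compound 2 (beyond the scatter), beyond the scatter, and a number 9.4 percentage points higher from compound 1 to compound 3 (within the scatter), within it. Within the data shown here, both point upward and neither is large, so a similar small upward step is expected for compound 4 in this assay; the numbers so far do not separate 2-chlorophenyl from phenyl or 4-fluorophenyl. The expected step is a number 9.2 percentage points higher from compound 1 to compound 4 (within the scatter). Compound 4 is estimated to give about 16%, with a range from 6% to 27%.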

Compound 4, a percentage reported as activity, at one concentration (the size of the read-out at that concentration, not a potency): 10.4%
Compound 4: the middle estimate sits 5.6 percentage points above what was measured, within the range that was stated.
By their numbers in this assay, from the lowest: compounds 1, 4, 3 and 2 (each within the scatter of the next, the first and the last beyond it).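

In this assay, within the data shown here, 2-chlorophenyl is the first group at this saturated ring carbon that cannot be separated from naphthalen-1-yl, phenyl or 4-fluorophenyl: the steps are a number 3.6 percentage points higher from compound 1 to compound 4 (within the scatter), a number 8.9 percentage points lower from compound 2 to compound 4 (within the scatter) and a number 5.8 percentage points lower from compound 3 to compound 4 (within the scatter). Exchanging naphthalen-1-yl for one six-membered aromatic ring of carbon only, with 3 fewer heavy atoms in the case of 2-chlorophenyl, therefore does not by itself give a step beyond the scatter; only compound 2 shows such a step from compound 1, while compound 3 and compound 4 go against that reading. Compound 4 likewise stays within the scatter of compound 2, and no measurement at hand accounts for any of these steps.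

The compounds shown leave open whether a group without an aromatic ring at this carbon, such as cyclohexyl or a longer alkyl chain, would change the read-out beyond the scatter. They also leave open what a dimethylamino group or a carboxylic acid on the phenyl ring would do.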